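The source may report more compounds than this note shows. Statements on the series, on what has been measured and on what is new or still open speak of the compounds shown alone.

In a functional assay (aorta) with Rattus norvegicus as the target, in the presence of a further agent that is not named here (a lower number here means that less compound is needed, a higher number that more compound is needed for the effect), the series so far:

Compound 1 `COC(=O)C1=C(C)N=C(C)/C(=C(/O)OC)C1c1ccccc1OCc1no[n+]([O-])c1C` gives 43 nM.
Compound 2 `COC(=O)C1=C(C)N=C(C)/C(=C(/O)OC)C1c1ccccc1OCc1c(C(N)=O)no[n+]1[O-]` gives 560 nM.
Compound 3 `COC(=O)C1=C(C)N=C(C)/C(=C(/O)OC)C1c1cccc(OCc2no[n+]([O-])c2C#N)c1` gives 3.3 nM.

Compound 2 has the highest of the three numbers, so it needs the most compound for the effect in this assay. The next structure to place is compound 4 `COC(=O)C1=C(C)N=C(C)/C(=C(/O)OC)C1c1ccccc1OCc1no[n+]([O-])c1C#N`. The change is a group of 8 heavy atoms (3 carbon, 3 nitrogen, 2 oxygen; one five-membered aromatic ring with 3 hetero atoms) in place of a group of 9 heavy atoms (3 carbon, 3 nitrogen, 3 oxygen; one five-membered aromatic ring with 3 hetero atoms), on a saturated chain carbon bound to an oxygen on an aromatic ring, on a saturated chain carbon bound to an oxygen on an aromatic ring.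

For the measured compounds named here, only one measured step changes a group at this place: a 13-fold higher number from compound 1 to compound 2 (1.11 log units; beyond the scatter). Going by the values given here, that large step ends at compound 2, whose group occurs in no other measured compound. Among the compounds with values here, compound 3 also carries a nitrile and gives 3.3 nM, but no measured step connects it to compound 2 or compound 1, so it is weak support. A single step cannot set the size of this change, and the replacement itself has not been measured. Losing the group of compound 2 is nevertheless expected to move the number down, by an amount similar to the one measured step. The expected step is a 9.3-fold lower number from compound 2 to compound 4 (0.97 log units; beyond the scatter), beyond the scatter. For compound 4 the estimated value is 60 nM, with an expected range from 12 nM to 300 nM.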

Compound 4, half-maximal effective concentration: 4.4 nM
For compound 4 the middle estimate is 14-fold (1.13 log units) above the measured one, outside the stated range (below it).
By their numbers in this assay, from the lowest: compounds 3 and 4 (each within the scatter of the next); then compound 1; then compound 2.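

In this assay, for the compounds shown here, the group on a saturated chain carbon bound to an oxygen on an aromatic ring proves to matter more than the single earlier step could show, with a 130-fold lower number from compound 2 to compound 4 (2.10 log units; beyond the scatter) as the largest step measured here. Compound 1 does not mark the low end at this place either, since cyano in place of methyl on an aromatic carbon gives a 9.8-fold lower number from compound 1 to compound 4 (0.99 log units; beyond the scatter) and so moves the number down without any group of compound 2 being involved. Compound 3 gives 3.3 nM and compound 4 gives 4.4 nM in this assay, values within the scatter of each other, so the two compounds carrying the nitrile sit together at the low end of the series, with no compound shown against this.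

Only methyl, cyano and the group of compound 2 are shown here, so it remains open whether a carboxylic acid, a trifluoromethyl or a longer chain on that aromatic carbon would track with cyano or with the group of compound 2. Nothing available here explains the size of these steps or separates the features that change together between compound 2 and compound 4.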